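This account rests on a few compounds, and the source may have more. Where it says the series, first, only, none or still open, it means among the compounds named here.

Compound 1 `Oc1cccc(-c2cc(-c3ccccc3F)cc(-c3cccc(O)c3)n2)c1` gives 11200 nM in a functional assay on DU-145 cells (Homo sapiens) for inhibition; on this read-out higher numbers stand for weaker inhibition and lower numbers for stronger inhibition; compound 2 `Oc1cccc(-c2cc(-c3cccc(F)c3)cc(-c3cccc(O)c3)n2)c1` gives 23800 nM; compound 3 `Oc1cccc(-c2cc(-c3ccc(F)cc3)cc(-c3cccc(O)c3)n2)c1` gives 7120 nM.

Compound 3 has the lowest number of the three: it sits clearly below compound 2, by a 3.3-fold lower number from compound 2 to compound 3 (0.52 log units; beyond the scatter), while its gap to compound 1, a 1.6-fold lower number from compound 1 to compound 3 (0.20 log units; within the scatter), is within the scatter. Compound 4 `Oc1ccc(-c2cc(-c3ccc(F)cc3)cc(-c3cccc(O)c3)n2)cc1` differs from compound 3 by 4-hydroxyphenyl in place of 3-hydroxyphenyl on an aromatic carbon. Among the compounds with values here, the measured steps all move the fluorine from one position of its phenyl ring to another, as in a 2.1-fold higher number from compound 1 to compound 2 (0.33 log units; beyond the scatter) and a 3.3-fold lower number from compound 2 to compound 3 (0.52 log units; beyond the scatter), and none moves a hydroxyl, so no step bears directly on this change; they show only that such positional shifts gave modest effects. A step of roughly a 1.2-fold higher number from compound 3 to compound 4 (0.08 log units; within the scatter) is therefore expected, with no confident direction. Compound 4 is estimated at 8500 nM, between 2500 nM and 28000 nM.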

Compound 4, half-maximal inhibitory concentration: 15200 nM
Beside the measured number, compound 4's estimate is 1.8-fold (0.25 log units) below it, and the stated range covers the measured number.
By their numbers in this assay, from the lowest: compounds 3, 1, 4 and 2 (each within the scatter of the next, the first and the last beyond it).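

Until now only the fluorine had moved; moving the hydroxyl shows that this ring is also sensitive to position, with a 2.1-fold higher number from compound 3 to compound 4 (0.33 log units; beyond the scatter) in this assay. The two compounds have the same atoms, joined differently, so rearranging the hydroxyl alone on the ring next to the ring nitrogen is enough to give a modest change. Nothing measured here offers an explanation for this shift.

Open, as far as these compounds go, is whether an amine or a methoxy group in place of this hydroxyl would keep the number near that of compound 3. Also open, from the compounds shown here alone, is how the other 3-hydroxyphenyl group would respond to the same move.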